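A few compounds are considered here, and "the series" means these few. Any claim that something is new, unique, unknown or untested is made for them only; others in the source may bear on it.

Measured so far:
compound 1, `O=C1OCCN1c1cc(C(F)(F)F)ccc1[C@H]1CCOc2cc(S(=O)(=O)Nc3nccs3)ccc21`, 295000 nM
compound 2, `Cn1nccc1-c1cc(C(F)(F)F)ccc1[C@H]1CCOc2cc(S(=O)(=O)Nc3cccc(F)n3)ccc21`, 27000 nM
compound 3, `O=S(=O)(Nc1ccncn1)c1ccc2c(c1)OCC[C@@H]2c1ccc(C(F)(F)F)cc1-c1ccc(F)cn1`, 181000 nM

In a physicochemical assay for solubility (on this read-out lower numbers stand for lower solubility and higher numbers for higher solubility), compound 1 gives the highest of the three numbers. Compound 3 lies within the scatter of compound 1, so no order between them can be claimed; compound 2 stands well below compound 1, beyond the scatter. Compound 4, `O=S(=O)(Nc1nccs1)c1ccc2c(c1)OCC[C@@H]2c1ccc(C(F)(F)F)cc1-c1ccc(F)nc1`, has not yet been measured. It differs from compound 1 in one place: 6-fluoropyridin-3-yl in place of 2-oxo-1,3-oxazolidin-3-yl on an aromatic carbon. Among the measured compounds shown here, no measured pair shows this exact change, so the size of the step rests on expectation alone. Compound 4 is expected to give a lower number than compound 1, a step of a 3.0-fold lower number from compound 1 to compound 4 (0.47 log units; beyond the scatter) that would be beyond the scatter. The estimate for compound 4 in this assay is 100000 nM, with a range from 30000 nM to 300000 nM.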

Compound 4, solubility: 21000 nM
For compound 4 the middle estimate is 4.8-fold (0.68 log units) above the measured one; measured number below the stated range.
By their numbers in this assay, from the lowest: compounds 4 and 2 (each within the scatter of the next); then compounds 3 and 1 (each within the scatter of the next).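

In this assay, among the compounds shown here, putting 6-fluoropyridin-3-yl in place of 2-oxo-1,3-oxazolidin-3-yl on this aromatic carbon gives a 14-fold lower number from compound 1 to compound 4 (1.15 log units; beyond the scatter), the first step at this position in which nothing else changes, and it shows that the read-out responds strongly to the group held here. No measured property is available to account for this step.

The compounds shown leave open how an amine or a carboxylic acid on this carbon would read in this assay, with the rest of compound 1 unchanged. They also leave open whether the same change would give a step of this size with different groups elsewhere in the molecule.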